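This account rests on a few compounds, and the source may have more. Where it says the series, first, only, none or still open, it means among the compounds named here.

- compound 1 `Cc1cc(-c2nc3sc(C)cn3c2/C=N/NC(=N)N)c(C)s1`: 19100 nM
- compound 2 `N=C(N)N/N=C/c1c(-c2cc(Cl)sc2Cl)nc2n1CCS2`: 15100 nM

In a functional assay on cells (Cancer cell lines, Homo sapiens) for inhibition (a higher number here means a weaker inhibitor of growth, a lower number a stronger inhibitor of growth), compound 1 gives 19100 nM and compound 2 gives 15100 nM, so compound 1 stands level with compound 2 within the scatter. Compound 3 `Cc1cc(-c2nc3sccn3c2/C=N/NC(=N)N)c(C)s1` differs from compound 1 by one change: hydrogen in place of methyl on an aromatic carbon. Going by the values given here, no measured pair shows this change, so the expectation in this assay is weakly grounded, and no step beyond the scatter is expected in either direction. The expected step is a 1.1-fold lower number from compound 1 to compound 3 (0.03 log units; within the scatter). For compound 3 the estimated value is 18000 nM, with an expected range of 9000 nM to 36000 nM.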

Compound 3, concentration for total growth inhibition: 26900 nM
Compound 3: the middle estimate sits 1.5-fold (0.17 log units) below what was measured, and the stated range covers the measured number.
By their numbers in this assay, from the lowest: compounds 2, 1 and 3 (each within the scatter of the next).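

In this assay, hydrogen in place of methyl on the aromatic carbon next to the ring sulfur gives a 1.4-fold higher number from compound 1 to compound 3 (0.15 log units; within the scatter). Going by these compounds alone, this is the first single-place comparison, and at this position the methyl can be exchanged for hydrogen with no step beyond the scatter. Nothing available explains the result at this position. As far as these compounds go, only methyl and hydrogen can be compared here, so the effect of an amine, a carboxylic acid or a longer chain at this carbon remains open. From the compounds shown here alone, whether the same exchange behaves alike on another compound of the series also remains open.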